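A few compounds are considered here, and "the series" means these few. Any claim that something is new, unique, unknown or untested is made for them only; others in the source may bear on it.

Compound 1 `Nc1ncc(-c2ccccc2)c(-c2ccccc2)n1`: 32%
Compound 2 `Cc1ccc(-c2cnc(N)nc2-c2ccccc2)cc1`: 51%
Compound 3 `Nc1ncc(-c2cccc(F)c2)c(-c2ccccc2)n1`: 63%

In an assay on CHO cells for displacement of a labelled ligand from adenosine receptor A1 (Homo sapiens), read by scintillation counting, with a stated time of 1 h, tested at 1 uM (a higher number here means more inhibition at the concentration tested (going by the name of the read-out), a lower number less inhibition), compound 2 stands second highest of the three: compound 3 lies higher and compound 1 lower, both beyond the scatter. Compound 4 `Nc1ncc(-c2ccc(F)cc2)c(-c2ccccc2)n1` differs from compound 2 by fluoro in place of methyl on an aromatic carbon. Within the data shown here, no measured step makes this exact swap. Among the measured compounds shown here, two steps bear on it indirectly, each adding a group to the same ring of compound 1: a number 19 percentage points higher from compound 1 to compound 2 (beyond the scatter) and a number 31 percentage points higher from compound 1 to compound 3 (beyond the scatter). Fluoro thus gave the larger gain, though compound 3 carries it elsewhere on that ring, so the swap from methyl to fluoro is expected to change little, with a number 4 percentage points higher from compound 2 to compound 4 (within the scatter). Compound 4 is therefore estimated at 55%, between 35% and 75%.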

Compound 4, a percentage reported as inhibition, at one concentration (the size of the read-out at that concentration, not a potency): > 80%
Compound 4: only a limit was reported; the forecaster's own chance of this, stated with the estimate: 0%; at least 25 percentage points between middle value and limit.
By their numbers in this assay, from the lowest: compound 1; then compound 2; then compound 3. At a limit, above all of these: compound 4.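

At this position, para to a large group, the choice of a single atom clearly matters: in this assay, fluoro in place of methyl gives a number at least 29 percentage points higher from compound 2 to compound 4 (beyond the scatter), and fluoro in place of hydrogen gives a number at least 48 percentage points higher from compound 1 to compound 4 (beyond the scatter). Methyl and fluoro, each one heavy atom, are therefore not interchangeable here, although the earlier compounds could only hint at this. The value for compound 4 is a limit, not a number: the limit of > 80% in this assay, at which 1 of the 4 values shown sits.

The compounds shown leave open whether chlorine, a methoxy group or an amine at this position would match fluoro. They also leave open whether a hydroxyl group would fall closer to methyl.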